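Phenethyl for 4-Bromophenyl on the Sulfur of Compound 1

The source may report more compounds than this note shows. Statements on the series, on what has been measured and on what is new or still open speak of the compounds shown alone.

Measured compounds:
Compound 1, `Nc1ccccc1NC(=O)c1ccc(CSc2ccc(Br)cc2)cc1`: 25.3%
Compound 2, `Nc1ccccc1NC(=O)/C=C/c1ccc(CSc2cccc(F)c2)cc1`: 8.25%

In a functional assay on SMMC-7721 cells (Homo sapiens) for inhibition, read by CCK-8 assay, with a stated time of 72 h, tested at 8 uM (on this read-out higher numbers stand for more inhibition of growth at the one concentration tested and lower numbers for less inhibition of growth), compound 1 gives 25.3%. Compound 2, which carries a different substituent on the sulfur and a different linker to the amide, gives 8.25% in this assay. Of the two numbers, compound 1 stands highest, and the gap down to compound 2 lies beyond the usual scatter. Since compound 1 and compound 2 differ in more than one place, neither change can be tied to that gap on its own.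

Compound 3, `Nc1ccccc1NC(=O)c1ccc(CSCCc2ccccc2)cc1`, differs from compound 1 in a single place: phenethyl in place of 4-bromophenyl on a sulfur. Within the data shown here, no pair of measured compounds separated by one change is available, so there is no measured step to lean on. The account therefore expects only a modest change in this assay, most likely a small drop that may not exceed the scatter, since the remaining structure is shared with compound 1, which gives 25.3%.

Compound 3 is estimated at 19%, with a range from 6% to 34%. This estimate means an expected step of a number 6.3 percentage points lower from compound 1 to compound 3 (within the scatter).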

Compound 3, percent growth inhibition at one concentration: 77.9%
Beside the measured number, compound 3's estimate is 58.9 percentage points below it, outside the stated range (above it).
By their numbers in this assay, from the lowest: compound 2; then compound 1; then compound 3.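

In this assay, among these compounds, phenethyl in place of 4-bromophenyl on a sulfur gives a step of a number 52.6 percentage points higher from compound 1 to compound 3 (beyond the scatter) and is the first change confined to one place, so it shows that the group on this sulfur strongly affects the read-out while the rest of the structure stays fixed. The change is not visible in several of the computed counts: both groups have one six-membered aromatic ring of carbon only, 0 hydrogen-bond donors, 0 hydrogen-bond acceptors and no net charge, and what differs is that 4-bromophenyl carries the bromine and phenethyl has 8 heavy atoms, all carbon, against 7. Nothing measured here accounts for the size of this step.

The compounds shown do not separate the loss of the bromine from the gain of the chain, and a plain phenyl or a benzyl on the sulfur would help divide the step. On these data alone, it also remains open whether a longer chain such as phenylpropyl, or an amine at the end of the chain, would hold the level of compound 3, and whether phenethyl would have the same effect with the linker of compound 2.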